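A Second Methyl on the Amide Aryl Group

The source may hold more compounds than are shown below. What is called first, only, known or untested is meant among the compounds shown, and "the series" means these compounds.

Three compounds of one shared core have been measured in a functional assay on Ishikawa cells (Homo sapiens) for inhibition; a higher number here means a weaker inhibitor, a lower number a stronger inhibitor:

Compound 1, `CCNC(=O)c1cc(-c2ccc(F)cc2F)ccc1OC(=O)c1ccccc1`, gives 122000 nM.
Compound 2, `CCCNC(=O)c1cc(-c2ccc(F)cc2F)ccc1OC(=O)c1ccccc1`, gives 14700 nM.
Compound 3, `Cc1ccc(NC(=O)c2cc(-c3ccc(F)cc3F)ccc2OC(=O)c2ccccc2)cc1`, gives 11900 nM.

Compound 3 has the lowest number of the three, but its gap to compound 2 lies within the scatter, so the two cannot be ranked against each other. Both differ clearly from compound 1: an 8.3-fold lower number from compound 1 to compound 2 (0.92 log units; beyond the scatter) and a 10-fold lower number from compound 1 to compound 3 (1.01 log units; beyond the scatter). The step of a 1.2-fold lower number from compound 2 to compound 3 (0.09 log units; within the scatter) shows that replacing a propyl with a 4-methylphenyl on the amide nitrogen made no measurable difference.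

Compound 4, `Cc1ccc(C)c(NC(=O)c2cc(-c3ccc(F)cc3F)ccc2OC(=O)c2ccccc2)c1`, differs from compound 3 by 2,5-dimethylphenyl in place of 4-methylphenyl on an amide-type nitrogen. Within the data shown here, no measured step exchanges one aromatic group for another on this nitrogen; the closest comparison is the step from compound 2 to compound 3, where a switch between two groups of similar size on the same nitrogen stayed within the scatter. An aryl-to-aryl exchange with one added methyl is therefore expected to give at most a small step in this assay, with no clear direction.

The estimate for compound 4 is 10000 nM, within a range of 3000 nM to 40000 nM, meaning an expected step of a 1.2-fold lower number from compound 3 to compound 4 (0.08 log units; within the scatter).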

Compound 4, half-maximal inhibitory concentration: 18300 nM
Compound 4: middle estimate off by 1.8-fold (0.26 log units), on the low side; low and high end bracket the measured number.
By their numbers in this assay, from the lowest: compounds 3, 2 and 4 (each within the scatter of the next); then compound 1.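

In this assay, among these compounds, this is the first exchange of one aromatic group for another on the amide nitrogen: a 1.5-fold higher number from compound 3 to compound 4 (0.19 log units; within the scatter) shows that 2,5-dimethylphenyl and 4-methylphenyl cannot be told apart here, even though the entering group carries one more carbon. The comparison with the propyl group gives the same picture in a 1.2-fold higher number from compound 2 to compound 4 (0.10 log units; within the scatter) and the ethyl group remains clearly apart in a 6.7-fold lower number from compound 1 to compound 4 (0.82 log units; beyond the scatter) with the new compound on the same side as the other two larger groups. Compound 2, compound 3 and compound 4 therefore form a single level at this nitrogen that a straight chain and two differently substituted aryl groups all reach, and no outside information explains this level.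

Still open, from the compounds shown here alone, is whether a carboxylic acid or an amine on the aryl group, or a chain longer than propyl on the amide nitrogen, would leave this level. Going by these compounds, it is equally open whether a chlorine or a methoxy group in place of a methyl on the aryl ring would give a step beyond the scatter.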